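This account rests on a few compounds, and the source may have more. Where it says the series, first, only, none or still open, it means among the compounds named here.

Working notes on the series. All three measured compounds share one core and differ only at the saturated chain carbon bound to a saturated ring carbon. Compound 1 `O=C1CCC(=O)N1C[C@H]1CN(c2ccc(-n3cc(-c4ccccn4)cn3)c(F)c2)C(=O)O1` carries 2,5-dioxopyrrolidin-1-yl there; in an ADME assay on HEK293-A cells (Homo sapiens) for cytotoxicity, read by MTT assay, with a stated time of 48 h (on this read-out higher numbers stand for weaker inhibition and lower numbers for stronger inhibition), compound 1 gives only a limit of the assay, > 400 ug/mL. Compound 2 `O=C1CSC(=O)N1C[C@H]1CN(c2ccc(-n3cc(-c4ccccn4)cn3)c(F)c2)C(=O)O1` carries 2,4-dioxo-1,3-thiazolidin-3-yl, and in this assay compound 2 gives 283 ug/mL. Compound 3 `O=C(OC[C@H]1CN(c2ccc(-n3cc(-c4ccccn4)cn3)c(F)c2)C(=O)O1)c1ccccc1` carries benzoyloxy; in this assay compound 3 gives a limit of the assay, > 400 ug/mL. The steps are small: an at least 1.4-fold lower number from compound 1 to compound 2 (0.15 log units; that floor lies within the scatter) and an at least 1.4-fold higher number from compound 2 to compound 3 (0.15 log units; that floor lies within the scatter), while a step that the two limits leave unreadable from compound 1 to compound 3 cannot be read because the limit of > 400 ug/mL in this assay, at which 2 of the 3 values shown sit, caps both values. Compound 3 thus stands at the ceiling of this assay, alongside compound 1.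

Compound 4 `O=C1O[C@@H](CSc2cccs2)CN1c1ccc(-n2cc(-c3ccccn3)cn2)c(F)c1` differs from compound 3 by (thiophen-2-yl)sulfanyl in place of benzoyloxy on a saturated chain carbon bound to a saturated ring carbon. For the measured compounds named here, the steps that bear on this position, from compound 1 to compound 2 and from compound 2 to compound 3, all lie within the scatter, so no step beyond the scatter is expected in this assay from compound 3 to compound 4, with the expected step being an at least 1.1-fold lower number from compound 3 to compound 4 (0.05 log units; that floor lies within the scatter). For compound 4 in this assay the estimate is 350 ug/mL, with a range from 150 ug/mL to 450 ug/mL, and a fair chance that again only a limit is reported.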

Compound 4, half-maximal inhibitory concentration: > 400 ug/mL
Compound 4: only a limit was reported; the forecaster's own chance of this, stated with the estimate: 55%; middle value at least 1.1-fold (0.05 log units) from the limit.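

For the compounds shown here, with (thiophen-2-yl)sulfanyl on a saturated chain carbon bound to a saturated ring carbon, a group holding a five-membered aromatic ring with 1 hetero atom now also reaches the ceiling of this assay, as the groups of compound 1 and compound 3 do, and compound 2 remains the only one with a number rather than a limit. Going by these compounds alone, the one new step that can be read is an at least 1.4-fold higher number from compound 2 to compound 4 (0.15 log units; that floor lies within the scatter). The new steps from compound 3 and from compound 1 to compound 4 cannot be read: the limit of > 400 ug/mL in this assay, at which 3 of the 4 values shown sit.

As far as these compounds go, how far compound 1, compound 3 and compound 4 lie past that limit stays open, and so does any order among them. Also open, from the compounds shown here alone, is whether an amine or a carboxylic acid at this position would give a step beyond the scatter in this assay.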